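Arylidene replacement in a fluorinated thioether series

The compounds below may be only part of what the source reports. "The series", "measured", "known", "first", "only" and "open" are said of these compounds alone.

Compound 2 `O=C(O)c1ccc(C(=O)/C(=C\c2ccc(F)c([N+](=O)[O-])c2)SCc2ccc(F)cc2)cc1` sits level with compound 1 `O=C(/C(=C\c1ccc(F)c([N+](=O)[O-])c1)SCc1ccc(F)cc1)c1ccc(F)cc1` and compound 3 `O=C(O)c1ccc(C(=O)/C(=C\c2ccc(F)c([N+](=O)[O-])c2)SCc2ccccc2Cl)cc1`: in a functional assay on DU-145 cells (Homo sapiens) for inhibition, read by trypan blue exclusion, with a stated time of 96 h (on this read-out higher numbers stand for weaker inhibition of growth and lower numbers for stronger inhibition of growth), compound 2 gives 1000 nM, compound 1 gives 1000 nM and compound 3 gives 1000 nM. The two measured steps, no change at the digits printed from compound 1 to compound 2 (within the scatter) and no change at the digits printed from compound 2 to compound 3 (within the scatter), both leave the read-out unchanged within the scatter, but neither touches the double-bonded chain carbon. Compound 4 `O=C(O)c1ccc(C(=O)/C(=C\c2ccc(Br)cc2)SCc2ccc(F)cc2)cc1` differs from compound 2 there: 4-bromophenyl in place of 4-fluoro-3-nitrophenyl on a double-bonded chain carbon bound to a double-bonded chain carbon. Going by the values given here, no measured step bears on this position, so the expectation rests only on the flatness of the series so far. Compound 4 is therefore expected to show no step beyond the scatter, no change at the digits printed from compound 2 to compound 4 (within the scatter). The estimate for compound 4 is 1000 nM, within a range of 300 nM to 3500 nM.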

Compound 4, concentration for 50% growth inhibition: > 100000 nM
Compound 4: no number, only a limit; the forecaster's own chance of this, stated with the estimate: 10%; middle value at least 100-fold (2.00 log units) from the limit.
By their numbers in this assay, from the lowest: compounds 1, 2 and 3 (each within the scatter of the next). At a limit, above all of these: compound 4.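

In this assay, going by these compounds alone, the group on the double-bonded chain carbon is the first place where a change moves the read-out, with an at least 100-fold higher number from compound 2 to compound 4 (2.00 log units; beyond the scatter) for 4-bromophenyl in place of 4-fluoro-3-nitrophenyl. Compound 4 is recorded only as a limit, > 100000 nM. The flat read-out across compounds 1, 2 and 3 therefore covers only the two places changed among them, not this one.

This step replaces the fluoro and the nitro together with a bromine, so it leaves open which of these accounts for the loss of growth inhibition. A 3-nitrophenyl group on this carbon would begin to separate them.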